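The source may hold more compounds than are shown below. What is called first, only, known or untested is meant among the compounds shown, and "the series" means these compounds.

Compound 3 `COc1ccc(CNC(=O)/C(C#N)=C/c2ccoc2)cc1` gives the lowest of the two numbers available in a functional assay on SMA cells (Homo sapiens) for inhibition, read by MTT assay, with a stated time of 72 h (a lower number here means a stronger inhibitor of growth, a higher number a weaker inhibitor of growth), at 7000 nM. Its nearest neighbour is compound 2 `COc1ccc(CNC(=O)/C(C#N)=C/c2ccc(Cl)o2)cc1`, which in this assay gives 14000 nM; the step of a 2.0-fold lower number from compound 2 to compound 3 (0.30 log units; within the scatter) does not rise above the scatter. Compound 1 `COc1ccc(CNC(=O)/C(C#N)=C/c2ccc[nH]2)cc1` reaches only a limit of the assay, > 50000 nM. Measured against that limit, the steps of an at least 3.5-fold lower number from compound 1 to compound 2 (0.55 log units; beyond the scatter) and an at least 7.1-fold lower number from compound 1 to compound 3 (0.85 log units; beyond the scatter) are each at least modest. Compound 4 `COc1ccc(CNC(=O)/C(C#N)=C/c2ccc(Cl)cc2)cc1` has not yet been measured. It differs from compound 3 in one place: 4-chlorophenyl in place of furan-3-yl on a double-bonded chain carbon bound to a double-bonded chain carbon. Every measured step here swaps one five-membered aromatic ring for another on that same chain carbon; none exchanges a five-membered ring for a six-membered ring of carbon only. The closest guide is the exchange of furan-3-yl for 5-chlorofuran-2-yl, which stayed within the scatter, and compound 2 already carries a chlorine as compound 4 does. On that basis the step of no change at the digits printed from compound 3 to compound 4 (within the scatter) is expected to stay within the scatter, with no clear direction. Compound 4 is therefore estimated to give 7000 nM in this assay, between 2500 nM and 20000 nM.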

Compound 4, concentration for 50% growth inhibition: 17000 nM
Compound 4: middle estimate off by 2.4-fold (0.39 log units), on the low side; measured number inside the range.
By their numbers in this assay, from the lowest: compounds 3, 2 and 4 (each within the scatter of the next, the first and the last beyond it). At a limit, above all of these: compound 1.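

Compound 4 brings the first six-membered ring of carbon only to this chain carbon, and in this assay the step of a 2.4-fold higher number from compound 3 to compound 4 (0.39 log units; beyond the scatter) is modest, so this exchange moves the reading beyond the scatter, which no exchange from furan-3-yl had done before. Set against the other chlorine-bearing ring, however, the step of a 1.2-fold higher number from compound 2 to compound 4 (0.08 log units; within the scatter) does not separate 4-chlorophenyl from 5-chlorofuran-2-yl, so changing the ring size between these two groups has no readable effect here. The step of an at least 2.9-fold lower number from compound 1 to compound 4 (0.46 log units; beyond the scatter) rests on a limit rather than a number, so it gives only a minimum size, and it places compound 4, like compounds 2 and 3, on the lower side of compound 1: the limit of > 50000 nM in this assay, at which 1 of the 4 values shown sits.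

From the compounds shown here alone, what a plain phenyl ring would give at this position stays open, so the part played by the chlorine in compound 4 cannot be separated from that of the six-membered ring. Also open, going by these compounds, is how a ring carrying an amine or a carboxylic acid, or a longer chain in place of the ring, would read in this assay.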